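A Bulkier Ether Group on a Weakly Cytotoxic Lactone

The compounds below may be only part of what the source reports. "The series", "measured", "known", "first", "only" and "open" are said of these compounds alone.

The compounds here share a chlorinated lactone core. Compound 1 `CCOC1OC(=O)C(Cl)=C1Cl` and compound 3 `CCCOC1OC(=O)C(Cl)=C1Cl` each carry two chlorines on that core, while compound 2 `CC(C)OC1OC(=O)C(Cl)=C1N1CCCCC1` carries one chlorine and a larger group in place of the other.

In an ADME assay on BEAS-2B cells (Homo sapiens) for cytotoxicity, read by MTT assay, with a stated time of 72 h (on this read-out lower numbers stand for stronger inhibition and higher numbers for weaker inhibition), compound 1 gives 3800 nM and compound 3 gives 3500 nM, and the step of a 1.1-fold lower number from compound 1 to compound 3 (0.04 log units; within the scatter) lies within the scatter. Compound 2 stands apart: in this assay compound 2 reaches only a limit of the assay, > 400000 nM. Among the three numbers shown, compound 2 is the one sitting at the limit of > 400000 nM in this assay, at which 1 of the 3 values shown sits, far from compounds 1 and 3.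

Compound 4 `CC(C)(C)COC1OC(=O)C(Cl)=C1N1CCCCC1` has not yet been measured. It differs from compound 2 by neopentyl in place of isopropyl on an oxygen on a saturated carbon. For the measured compounds named here, the only measured step that resembles this, a lengthening of the chain on the ether oxygen, is a 1.1-fold lower number from compound 1 to compound 3 (0.04 log units; within the scatter), within the scatter. A change of similar size is therefore expected for compound 4 in this assay, none beyond the scatter, meaning a step that the limit leaves unreadable from compound 2 to compound 4. Compound 4 is expected to give about 500000 nM, between 150000 nM and 2000000 nM, most likely again reported only as a limit.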

Compound 4, half-maximal inhibitory concentration: > 400000 nM
Compound 4: no number, only a limit; the forecaster's own chance of this, stated with the estimate: 80%; the middle value is on the limit's open side.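

Compound 2 and compound 4 both reach only a limit in this assay, so no size can be read for the change from isopropyl to neopentyl: the limit of > 400000 nM in this assay, at which 2 of the 4 values shown sit.

Left open is how far beyond that limit each compound lies, and whether this change alters cytotoxicity at all.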